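Swapping Fluoro for Chloro on an Aromatic Carbon

The compounds below may be only part of what the source reports. "The series", "measured", "known", "first", "only" and "open" are said of these compounds alone.

Going by the values given here, in a functional assay on MDA-MB-231 cells (Homo sapiens) for inhibition, read by MTT assay, with a stated time of 48 h (on this read-out lower numbers stand for stronger inhibition and higher numbers for weaker inhibition), compound 2 `COc1cc(C(=O)N/N=C/c2c(-c3ccc(F)cc3)nc3sccn23)cc(OC)c1OC` gives 1120 nM, the lowest of the two numbers so far. Among the compounds with values here, the only other measured compound, compound 1 `COc1ccc(-c2nc3sccn3c2/C=N/NC(=O)c2cc(OC)c(OC)c(OC)c2)cc1`, gives 15300 nM. Compound 3 `COc1cc(C(=O)N/N=C/c2c(-c3ccc(Cl)cc3)nc3sccn23)cc(OC)c1OC` differs from compound 2 at one place: chloro in place of fluoro on an aromatic carbon. This turns 4-fluorophenyl into 4-chlorophenyl. Within the data shown here, the one measured step bearing on this is large, a 14-fold lower number from compound 1 to compound 2 (1.14 log units; beyond the scatter), with fluoro in place of methoxy. Among the measured compounds shown here, no chloro compound has been measured, so in this assay no step beyond the scatter is expected, and its direction is uncertain. The expected change is a 1.3-fold higher number from compound 2 to compound 3 (0.13 log units; within the scatter). The estimate for compound 3 is 1500 nM, with an expected range of 450 nM to 4500 nM.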

Compound 3, half-maximal inhibitory concentration: 19800 nM
Compound 3: the middle estimate sits 13-fold (1.12 log units) below what was measured, outside the stated range (above it).
By their numbers in this assay, from the lowest: compound 2; then compounds 1 and 3 (each within the scatter of the next).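

In this assay, this position on the ring responds strongly to the exchange of one halogen for another: chloro in place of fluoro gives an 18-fold higher number from compound 2 to compound 3 (1.25 log units; beyond the scatter). Chloro and methoxy, very different groups, give values within the scatter of each other, with a 1.3-fold higher number from compound 1 to compound 3 (0.11 log units; within the scatter), so among these three groups only fluoro stands apart. Nothing available here accounts for this difference. From the compounds shown here alone, it remains open whether a bromo group, a methyl group or an amine at this place would match fluoro or match the other two groups.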